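Dimethylamide in place of morpholine amide on the shared core

The source may report more compounds than this note shows. Statements on the series, on what has been measured and on what is new or still open speak of the compounds shown alone.

Going by the values given here, all three compounds measured so far share a core and were tested in an assay on isolated protein for inhibition of MAP kinase-interacting serine/threonine-protein kinase 1 (Homo sapiens), read by HTRF, in the presence of a further agent that is not named here; a lower number here means a stronger inhibitor, a higher number a weaker inhibitor. Compound 1 (`CNC(=O)c1cccc(C#Cc2ccccc2Nc2ncnc3ccc(Cl)nc23)c1`) carries a methylamino group on its carbonyl carbon. In this assay compound 1 gives > 10000 nM, which is a limit of the assay. Compound 3 (`COC(=O)c1cccc(C#Cc2ccccc2Nc2ncnc3ccc(Cl)nc23)c1`) replaces that methylamino with a methoxy group on the carbonyl carbon. In this assay compound 3 gives > 10000 nM, again only a limit. The step that the two limits leave unreadable from compound 1 to compound 3 therefore cannot be read. Compound 2 (`Cc1c(C(=O)N2CCOCC2)oc2ccc(Nc3ncnc4ccc(Cl)nc34)cc12`) belongs to a different series on the same core and carries a morpholin-4-yl on its carbonyl carbon. In this assay compound 2 gives > 10000 nM, which is a limit and not a number, so compound 2 stands where every value shown so far stands, namely at the limit of > 10000 nM in this assay, at which 3 of the 3 values shown sit.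

Compound 4 (`Cc1c(C(=O)N(C)C)oc2ccc(Nc3ncnc4ccc(Cl)nc34)cc12`) differs from compound 2 by dimethylamino in place of morpholin-4-yl on a carbonyl carbon. Among the compounds with values here, no measured step bears on this change, and the one step recorded is unreadable. Compound 4 is therefore expected to sit at the same limit as compound 2, with no readable step that the limit leaves unreadable from compound 2 to compound 4 in this assay. The estimate for compound 4 in this assay is 15000 nM, within 3000 nM to 60000 nM.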

Compound 4, half-maximal inhibitory concentration: > 10000 nM
Compound 4: a limit, no number; the forecaster's own chance of this, stated with the estimate: 75%; the middle value does not contradict the limit.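

In this assay compound 4, like compound 2, gives only a limit and not a number, so no step can be read for dimethylamino in place of morpholin-4-yl. All values shown stand together: the limit of > 10000 nM in this assay, at which 4 of the 4 values shown sit.

Which group on the carbonyl carbon, if any, would give a readable number in this assay stays open.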